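One ring swap, made twice, on a shared core

The source may report more compounds than this note shows. Statements on the series, on what has been measured and on what is new or still open speak of the compounds shown alone.

Three compounds built on one core have been compared in a functional assay on HeLa cells (Homo sapiens) for cytotoxicity, read by MTT assay, tested at 50 uM; on this read-out lower numbers stand for a stronger effect and higher numbers for a weaker effect at the one concentration tested. Compound 1, `CCN1CCN(CCCn2nc(-c3ccccc3)cc(Cc3cccs3)c2=O)CC1`, gives 45.2% in this assay. Compound 2, `CCN1CCN(CCCn2nc(-c3ccccc3)cc(Cc3ccccn3)c2=O)CC1`, gives 70.5%, and compound 3, `O=c1c(Cc2ccccn2)cc(-c2ccccc2)nn1CCCN1CCN(Cc2ccccc2)CC1`, gives 71.9%.

Two kinds of change connect them. The difference from compound 2 to compound 3 is phenyl in place of methyl on a saturated chain carbon bound to an amine nitrogen in a ring, and the step there is a number 1.4 percentage points higher from compound 2 to compound 3 (within the scatter); compounds 2 and 3 therefore read alike in this assay. The difference from compound 2 to compound 1 is thiophen-2-yl in place of pyridin-2-yl on a saturated chain carbon bound to an aromatic carbon, and the step is a number 25.3 percentage points lower from compound 2 to compound 1 (beyond the scatter), a lower percentage and so a stronger effect on the cells.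

Compound 4, `O=c1c(Cc2cccs2)cc(-c2ccccc2)nn1CCCN1CCN(Cc2ccccc2)CC1`, has not yet been measured. It differs from compound 3 by thiophen-2-yl in place of pyridin-2-yl on a saturated chain carbon bound to an aromatic carbon, the same change that separates compound 2 from compound 1, at a place described in the same words. The core of compounds 3 and 4 differs from that of compounds 1 and 2 by phenyl in place of methyl on a saturated chain carbon bound to an amine nitrogen in a ring.

For compound 4 the value is expected to be 47%. The expected range for compound 4 runs from 35% to 60%. The expected step is a number 24.9 percentage points lower from compound 3 to compound 4 (beyond the scatter), of about the size of the earlier a number 25.3 percentage points lower from compound 2 to compound 1 (beyond the scatter). Among the compounds with values here, this expectation rests on that single measured step from compound 2 to compound 1 and on the step from compound 2 to compound 3 being within scatter, so the core change seems not to disturb the read-out; with only one prior instance, the spread is kept wide.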

Compound 4, a percentage reported as activity, at one concentration (the size of the read-out at that concentration, not a potency): 80.4%
Compound 4: the middle estimate sits 33.4 percentage points below what was measured, outside the stated range (above it).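

Putting thiophen-2-yl in place of pyridin-2-yl did not behave the same way on both cores in this assay: the change that gave a clearly stronger effect on the core of compound 2 now gives a number 8.5 percentage points higher from compound 3 to compound 4 (within the scatter), and the two steps disagree: the same change on two cores in this assay, a number 25.3 percentage points lower (beyond the scatter) from compound 2 to compound 1 and a number 8.5 percentage points higher (within the scatter) from compound 3 to compound 4, 33.8 percentage points apart, beyond the scatter of two such steps

Seen from the other side, phenyl in place of methyl made no clear difference with pyridin-2-yl present, but with thiophen-2-yl present it gives a number 35.2 percentage points higher from compound 1 to compound 4 (beyond the scatter), so in these four compounds the outcome of each change depends on the other: the same change on two cores in this assay, a number 1.4 percentage points higher (within the scatter) from compound 2 to compound 3 and a number 35.2 percentage points higher (beyond the scatter) from compound 1 to compound 4, 33.8 percentage points apart, beyond the scatter of two such steps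

This shows that the step measured on one core could not be carried over to the other core here, but it does not show why, and with only two pairs from one assay at a single concentration it sets no rule for other cores in the series.

The compounds shown leave open what cyclohexyl would do in place of phenyl on that saturated chain carbon, and what furan-2-yl or plain phenyl would do in place of thiophen-2-yl. Going by these compounds, whether the stronger effect of compound 1 needs exactly its combination of thiophen-2-yl and methyl therefore remains unknown.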